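Triaryl pyridine hydroxyphenyl isomers: cytotoxicity notes

The source may hold more compounds than are shown below. What is called first, only, known or untested is meant among the compounds shown, and "the series" means these compounds.

Measured compounds:
- compound 1, `Oc1ccc(-c2cc(-c3cccc(O)c3)nc(-c3cccc(O)c3)c2)cc1`: 730 nM
- compound 2, `Oc1cccc(-c2cc(-c3cccc(O)c3)nc(-c3ccccc3O)c2)c1`: a limit, > 50000 nM
- compound 3, `Oc1ccc(-c2cc(-c3cccc(O)c3)cc(-c3cccc(O)c3)n2)cc1`: 1560 nM

In an ADME assay on HEK293 cells (Homo sapiens) for cytotoxicity, read by CCK-8 assay, with a stated time of 4 days (on this read-out higher numbers stand for weaker inhibition and lower numbers for stronger inhibition), compound 3 gives 1560 nM and stands highest of the two numbers shown. Within the data shown here, compound 1 sits nearest to it, and the gap between compound 3 and compound 1 lies beyond the scatter; the two are isomers of the shared core and no single step between them is counted here. For compound 2 this assay reports only a limit, > 50000 nM, not a number.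

Among the measured compounds shown here, the one counted step that touches this position is an at least 32-fold lower number from compound 2 to compound 3 (1.50 log units; beyond the scatter). Its size is bounded by the limit of > 50000 nM in this assay, at which 1 of the 3 values shown sits, so only the direction and a floor are known.

Compound 4, `Oc1cccc(-c2cc(-c3cccc(O)c3)nc(-c3cccc(O)c3)c2)c1`, differs from compound 3 by 3-hydroxyphenyl in place of 4-hydroxyphenyl on an aromatic carbon. The change leaves the hydroxyl on the phenyl ring but shifts it from the 4-position to the 3-position, giving a compound in which all three aryl groups are 3-hydroxyphenyl. Compound 1 already carries 3-hydroxyphenyl next to the ring nitrogen and gives 730 nM, which argues against any large move.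

The expected step is therefore a 1.6-fold lower number from compound 3 to compound 4 (0.19 log units; within the scatter), within the scatter. Compound 4 is estimated at 1000 nM, with a range from 350 nM to 3000 nM.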

Compound 4, half-maximal inhibitory concentration: 740 nM
For compound 4 the middle estimate is 1.4-fold (0.13 log units) above the measured one; the range from low to high includes it.
By their numbers in this assay, from the lowest: compounds 1 and 4 (each within the scatter of the next); then compound 3. At a limit, above all of these: compound 2.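

At the aromatic carbon next to the ring nitrogen, 3-hydroxyphenyl in place of 4-hydroxyphenyl gives a 2.1-fold lower number from compound 3 to compound 4 (0.32 log units; beyond the scatter) in this assay, so the placement of the hydroxyl on this phenyl ring registers here, though the step is modest. The same exchange at another aryl position of the shared core gives a 1.0-fold higher number from compound 1 to compound 4 (0.01 log units; within the scatter), so within these compounds the exchange reads differently at the two places. At the position next to the ring nitrogen, 3-hydroxyphenyl in place of 2-hydroxyphenyl gives a far larger change, an at least 67-fold lower number from compound 2 to compound 4 (1.82 log units; beyond the scatter), and only a floor is known for that step: the limit of > 50000 nM in this assay, at which 1 of the 4 values shown sits.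

As far as these compounds go, what a methoxy group, an amine or a carboxylic acid would do in place of the hydroxyl at this position stays open. The compounds shown also leave open whether 2-hydroxyphenyl at the other aryl positions of the shared core would produce a change of similar size in this assay.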